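A few compounds are considered here, and "the series" means these few. Any claim that something is new, unique, unknown or untested is made for them only; others in the source may bear on it.

Compound 1 `CC(C)[C@H](NC(=O)COc1cccc2ccccc12)C(=O)N[C@@H](CC(=O)O)C(=O)CSc1nncn1C` gives > 200000 nM in a functional assay on Jurkat cells (Homo sapiens) for inhibition (a higher number here means a weaker inhibitor, a lower number a stronger inhibitor), a limit of the assay rather than a number.
Compound 2 `CC(C)[C@H](NC(=O)COc1cccc2ccccc12)C(=O)N[C@@H](CC(=O)O)C(=O)CSc1nc2ccccc2o1` gives > 200000 nM in this assay, again a limit.
Compound 3 `CC(C)[C@H](NC(=O)COc1cccc2ccccc12)C(=O)N[C@@H](CC(=O)O)C(=O)COc1ncnc2ccccc12` gives > 200000 nM in this assay, also a limit.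

All three values sit at the limit of > 200000 nM in this assay, at which 3 of the 3 values shown sit, so compound 2 stands only at a limit, with no number of its own. Compound 4 `CC(C)[C@H](NC(=O)COc1cccc2ccccc12)C(=O)N[C@@H](CC(=O)O)C(=O)COc1cncc2ccccc12` differs from compound 2 by (isoquinolin-4-yl)oxy in place of (1,3-benzoxazol-2-yl)sulfanyl on a saturated chain carbon bound to a carbonyl carbon. The steps a step that the two limits leave unreadable from compound 1 to compound 2, a step that the two limits leave unreadable from compound 1 to compound 3 and a step that the two limits leave unreadable from compound 2 to compound 3 are all unreadable, so no size or direction of step can be drawn from them for this change. Compound 3, which also carries an oxygen-linked bicyclic group at the same place, stays at the limit, and compound 4 is expected to do the same, the estimated step being a step that the limit leaves unreadable from compound 2 to compound 4. Compound 4 is therefore estimated at 300000 nM, within 100000 nM to 1000000 nM.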

Compound 4, half-maximal inhibitory concentration: 166000 nM
Compound 4: the middle estimate sits 1.8-fold (0.26 log units) above what was measured; the measured number falls inside the stated range.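

Placing (isoquinolin-4-yl)oxy on the saturated chain carbon bound to a carbonyl carbon gives the first readable steps at this position in this assay, with an at least 1.2-fold lower number from compound 2 to compound 4 (0.08 log units; that floor lies within the scatter), an at least 1.2-fold lower number from compound 3 to compound 4 (0.08 log units; that floor lies within the scatter) and an at least 1.2-fold lower number from compound 1 to compound 4 (0.08 log units; that floor lies within the scatter). Each is only a floor, so none of these steps is yet shown to exceed the usual scatter. Compound 4 alone has a number of its own, and the other compounds stay at a limit: the limit of > 200000 nM in this assay, at which 3 of the 4 values shown sit.

From the compounds shown here alone, the true gaps between compound 4 and the other compounds remain open. Also open, going by these compounds, is how an amine or a plain phenoxy group would behave at this position.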